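The source may report more compounds than this note shows. Statements on the series, on what has been measured and on what is new or still open speak of the compounds shown alone.

Measured in an ADME assay on Raji cells (Homo sapiens) for cytotoxicity, with a stated time of 72 h; a lower number here means that less compound is needed, a higher number that more compound is needed for the effect:
Compound 1 `Cc1cc(NC(=O)Nc2ccc(F)cc2)c2ccccc2n1`: > 25000 nM (a limit of the assay)
Compound 2 `Cc1cc(NC(=O)Nc2ccc(SC(F)(F)F)cc2)c2ccccc2n1`: 10000 nM

For the measured compounds named here, compound 2, at 10000 nM, holds the only true number in this assay. Compound 1 gives only a limit, > 25000 nM.

Compound 3 `Cc1cc(NC(=O)Nc2ccc(Cl)cc2)c2ccccc2n1` keeps the core of compound 2 and has chloro in place of (trifluoromethyl)sulfanyl on an aromatic carbon, para to a large group: chloro in place of (trifluoromethyl)sulfanyl on an aromatic carbon.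

A single measured step bears on this change, and it concerns the same place. It is an at least 2.5-fold lower number from compound 1 to compound 2 (0.39 log units; beyond the scatter), where (trifluoromethyl)sulfanyl took the place of fluoro. Its size is known only in part, since one end is a limit. Compound 3 gives up the group that compound 2 carries, so part of that step may well be reversed, and a move to a higher number is expected in this assay. The size of this move is uncertain, and a result at the limit of the assay would be no surprise. The expected change is a 1.8-fold higher number from compound 2 to compound 3 (0.26 log units; within the scatter). For compound 3 the estimated value is 18000 nM, with an expected range from 9000 nM to 36000 nM.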

Compound 3, half-maximal effective concentration: > 25000 nM
Compound 3 ended at the assay's limit (the forecaster's own chance of this, stated with the estimate: 35%); middle value at least 1.3-fold (0.14 log units) from the limit.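

Replacing (trifluoromethyl)sulfanyl with chloro on the aromatic carbon, para to a large group, gives an at least 2.5-fold higher number from compound 2 to compound 3 (0.39 log units; beyond the scatter) in this assay. Until now, only fluoro had been compared with (trifluoromethyl)sulfanyl at this position; the chloro result shows that compound 2 also stands apart from a second compound that differs from it only here. Of the three compounds, only compound 2 gives a true number, and with either fluoro or chloro in place of its (trifluoromethyl)sulfanyl group the result falls at the limit of the assay: the limit of > 25000 nM in this assay, at which 2 of the 3 values shown sit.

Both ends of the step from compound 1 to compound 3 are limits, so that step cannot be read, and the compounds shown do not tell how far either compound lies past the limit or how chloro and fluoro compare. Also open, going by these compounds, is where an amine, a methoxy group, a trifluoromethyl group or a carboxylic acid on this same aromatic carbon would fall in this assay, and whether the sulfur atom or the trifluoromethyl part of the group in compound 2 matters more.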